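Working notes: urea in place of the ring acyl

The source may report more compounds than this note shows. Statements on the series, on what has been measured and on what is new or still open speak of the compounds shown alone.

Measured compounds:
compound 1 `C[C@@H](O[C@@H]1CN(C(=O)[C@@H]2CCC(=O)N2C)C[C@H]1c1ccc(F)cc1)c1cc(C(F)(F)F)cc(C(F)(F)F)c1` — in an assay on CHO cells for displacement of a labelled ligand from Substance-P receptor (Homo sapiens) (a lower number here means a stronger inhibitor, a higher number a weaker inhibitor), compound 1 gives 0.12 nM
compound 2 `C[C@@H](O[C@@H]1CN(C(=O)[C@@H]2COC(=O)N2)C[C@H]1c1ccc(F)cc1)c1cc(C(F)(F)F)cc(C(F)(F)F)c1` — in this assay compound 2 gives 0.34 nM

For the measured compounds named here, compound 2 holds the higher of the two numbers in this assay; its only neighbour is compound 1, and the sole measured step is a 2.8-fold higher number from compound 1 to compound 2 (0.45 log units; beyond the scatter), a modest change that lies beyond the scatter.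

Compound 3 `CC(C)NC(=O)N1C[C@@H](O[C@H](C)c2cc(C(F)(F)F)cc(C(F)(F)F)c2)[C@H](c2ccc(F)cc2)C1` differs from compound 2 by isopropylamino in place of 2-oxo-1,3-oxazolidin-4-yl on a carbonyl carbon. Going by the values given here, no measured pair covers a carbamoyl in place of a ring acyl on this carbonyl, so the single step above is the only guide. It shows that exchanging the group on the carbonyl of the shared core shifts this assay by a modest amount. On that basis a step in the same direction, again modest and near the edge of the scatter, is expected for compound 3: a 2.1-fold higher number from compound 2 to compound 3 (0.31 log units; beyond the scatter). Compound 3 is therefore estimated at 0.7 nM in this assay, with a range from 0.15 nM to 3.5 nM.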

Compound 3, half-maximal inhibitory concentration: 0.06 nM
Beside the measured number, compound 3's estimate is 12-fold (1.07 log units) above it; the measured number lies below the stated range.
By their numbers in this assay, from the lowest: compounds 3 and 1 (each within the scatter of the next); then compound 2.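

For the compounds shown here, the acyclic isopropylamino group, with no ring and no defined stereocentre, moves the number in this assay the opposite way to the first step: a 5.7-fold lower number from compound 2 to compound 3 (0.75 log units; beyond the scatter). The ring acyl is therefore not needed on this carbonyl carbon, and exchanging the group there can lower the number as well as raise it. Against the other ring acyl there is a 2.0-fold lower number from compound 1 to compound 3 (0.30 log units; within the scatter), so compound 3 and compound 1 cannot be told apart in this assay, and compound 2, with its 2-oxo-1,3-oxazolidin-4-yl group, is the only one set apart from both; no supporting data bear on this result.

With a single isopropylamino compound, the series gives no trend among groups on the urea nitrogen, so a dimethylamino group on this carbonyl would show whether the hydrogen on that nitrogen matters to the number. A methylamino group and a longer n-butylamino chain would show how far the number follows the size of the alkyl group.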